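Ring-Bearing Amide at the Ring Nitrogen of the Shared Core

The source may report more compounds than this note shows. Statements on the series, on what has been measured and on what is new or still open speak of the compounds shown alone.

Compound 1 `CCCCNc1nc(N)nc2c1CN(C(C)=O)CC2` gives 0.5 uM in an assay on HEK293 cells for agonist activity at Toll-like receptor 8 (Homo sapiens), read by a luciferase reporter, with a stated time of 6 h; a lower number here means that less compound is needed, a higher number that more compound is needed for the effect.
Compound 2 `CCCCNc1nc(N)nc2c1CN(Cc1ccco1)CC2` gives 0.08 uM in this assay.
Compound 3 `CCCCNc1nc(N)nc2c1CN(C(=O)CC)CC2` gives 0.4 uM in this assay.

Among these three numbers, compound 3 stands second highest: it sits within the scatter of compound 1, with a 1.3-fold lower number from compound 1 to compound 3 (0.10 log units; within the scatter), while compound 2 lies clearly apart, with a 5.0-fold higher number from compound 2 to compound 3 (0.70 log units; beyond the scatter). Compound 4 `CCCCNc1nc(N)nc2c1CN(C(=O)c1scnc1C)CC2` is not yet measured. It differs from compound 3 by 4-methyl-1,3-thiazol-5-yl in place of ethyl on a carbonyl carbon. Going by the values given here, two measured steps bear on this, though only loosely. Exchanging acetyl on the ring nitrogen for (furan-2-yl)methyl gave a 6.3-fold lower number from compound 1 to compound 2 (0.80 log units; beyond the scatter), and the reverse exchange to propanoyl gave a 5.0-fold higher number from compound 2 to compound 3 (0.70 log units; beyond the scatter). In compound 4 the carbonyl stays and a five-membered aromatic ring enters on it, so the change goes only part of the way toward what compound 2 shows. A modest lowering of the number in this assay is therefore expected, smaller than the step seen with compound 2 and with wide uncertainty. Compound 4 is estimated at 0.2 uM, within 0.05 uM to 0.8 uM, which means an expected step of a 2.0-fold lower number from compound 3 to compound 4 (0.30 log units; within the scatter).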

Compound 4, minimum effective concentration: 5.6 uM
For compound 4 the middle estimate is 28-fold (1.45 log units) below the measured one; the measured number lies above the stated range.
By their numbers in this assay, from the lowest: compound 2; then compounds 3 and 1 (each within the scatter of the next); then compound 4.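

In this assay the methyl of compound 1 and the ethyl of compound 3 on the carbonyl carbon give numbers within the scatter of each other, so this place seemed tolerant of change, yet 4-methyl-1,3-thiazol-5-yl there gives a 14-fold higher number from compound 3 to compound 4 (1.15 log units; beyond the scatter) and an 11-fold higher number from compound 1 to compound 4 (1.05 log units; beyond the scatter) as well. A five-membered aromatic ring is therefore no advantage in itself at this ring nitrogen: held on a carbonyl rather than on the methylene of compound 2, it comes with a 70-fold higher number from compound 2 to compound 4 (1.85 log units; beyond the scatter) and gives the highest number of the four. Nothing measured here accounts for the size of these steps.

The compounds shown cannot separate the thiazole ring from its methyl group, which a plain 1,3-thiazol-5-yl or a phenyl on the carbonyl could begin to do. Going by these compounds, whether a longer chain than ethyl on the carbonyl stays close to compound 1 and compound 3 also remains open.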